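The source may report more compounds than this note shows. Statements on the series, on what has been measured and on what is new or still open speak of the compounds shown alone.

In a functional assay on A549 cells (Homo sapiens) for inhibition, read by MTT assay, with a stated time of 72 h (a lower number here means a stronger inhibitor, a higher number a weaker inhibitor), compound 1 `Nc1nc2cc(-c3nn(CCCCCCCCCC(=O)NO)c4ncnc(N)c34)ccc2o1` stands at > 50000 nM, which is a limit of the assay and not a number. Compound 4 `Nc1nc2cc(-c3nn(CCCCCC(=O)NO)c4ncnc(N)c34)ccc2o1` keeps the core of compound 1 but has a shorter chain: hydroxycarbamoyl in place of 4-(hydroxycarbamoyl)butyl on a saturated chain carbon, five bonds along the chain from an aromatic nitrogen. Compound 2 `Nc1ncnc2c1c(-c1cnc3[nH]ccc3c1)nn2CCCCCCCCCC(=O)NO`, with the same long chain and another group on the core, gives 6550 nM. That step, an at least 7.6-fold lower number from compound 1 to compound 2 (0.88 log units; beyond the scatter), is beyond the scatter, but it concerns the group on the core and not the chain. Shortening the chain of compound 2 gives compound 3 `Nc1ncnc2c1c(-c1cnc3[nH]ccc3c1)nn2CCC(=O)NO`, and compound 3 stands at a limit, > 150000 nM, so a shorter chain shows no gain here. No clear step is therefore expected, and the estimated change is a number no higher from compound 1 to compound 4 (the limit leaves the size open). For compound 4 the expected value is 50000 nM, within an estimated range of 8000 nM to 200000 nM.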

Compound 4, half-maximal inhibitory concentration: > 100000 nM
Compound 4: a limit, no number; the forecaster's own chance of this, stated with the estimate: 55%; middle value at least 2.0-fold (0.30 log units) away from the limit.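

Compound 1 and compound 4 both give limits and not numbers, so the step between them cannot be read. As far as these compounds go, whether the shorter chain of compound 4 changes activity on the shared core stays open.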